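A fluorine enters the phenylethyl group on sulfur

The source may report more compounds than this note shows. Statements on the series, on what has been measured and on what is new or still open speak of the compounds shown alone.

Of the compounds shown here, three sharing one core have been measured in an assay on isolated protein for inhibition of Retinaldehyde dehydrogenase 3 (Homo sapiens); a higher number here means a weaker inhibitor, a lower number a stronger inhibitor. Compound 1 `CC(Sc1nc2nn(CC3COC3)cc2c(=O)n1-c1ccccc1)c1ccccc1` gives 60 nM in this assay. Compound 2 `CC(Sc1nc2c(cnn2C)c(=O)n1-c1ccc(CO)cc1)c1ccccc1` gives 1000 nM in this assay. Compound 3 `C[C@@H](Sc1nc2c(cnn2C)c(=O)n1-c1ccccc1)c1ccccc1` gives 34 nM in this assay, the lowest of the three numbers. Compound 1 and compound 3 sit within the scatter of one another, so nothing can be said of their order. Compound 2, which carries a hydroxymethyl group on the phenyl attached to the core, sits far beyond the scatter from compound 3.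

Compound 4 `CC(Sc1nc2c(cnn2C)c(=O)n1-c1ccccc1)c1cccc(F)c1` has not yet been measured. It differs from compound 3 in one place: 1-(3-fluorophenyl)ethyl in place of 1-phenylethyl on a sulfur. The core, the sulfur link and the phenyl on the core stay as they are; the only new atom is one fluorine on the ring that hangs from the sulfur.

For the measured compounds named here, no step between two measured compounds is known that would show what such a change does here. On that basis the step in this assay is expected to be small, with no direction that goes beyond the scatter, and the expected step from compound 3 to compound 4 is a 1.1-fold lower number from compound 3 to compound 4 (0.05 log units; within the scatter). Compound 4 is therefore estimated at 30 nM in this assay, with a range from 10 nM to 90 nM.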

Compound 4, half-maximal inhibitory concentration: 128 nM
Compound 4: middle estimate off by 4.3-fold (0.63 log units), on the low side; measured number above the stated range.
By their numbers in this assay, from the lowest: compounds 3 and 1 (each within the scatter of the next); then compound 4; then compound 2.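

In this assay, for the compounds shown here, the group on the sulfur turns out to matter: 1-(3-fluorophenyl)ethyl in place of 1-phenylethyl gives a 3.8-fold higher number from compound 3 to compound 4 (0.58 log units; beyond the scatter) and so moves toward a weaker inhibitor, in the first step that can be read at this position. The step is modest, but it lies beyond the scatter, so the ring hanging from the sulfur does not tolerate this single added fluorine without a measurable change. Nor is it a clean reading of the fluorine alone: the 1-phenylethyl of compound 3 has one defined stereocentre, the 1-(3-fluorophenyl)ethyl of compound 4 has none defined, and the two differences travel together in this one place, with nothing at hand to give a reason for the step.

Still open, going by these compounds, is what the 1-(3-fluorophenyl)ethyl group gives with its stereocentre defined, and whether a chlorine, a methoxy group or a nitrile on that ring would go the same way as the fluorine. Also open, on these data alone, is whether the same change reads alike with the hydroxymethyl-bearing phenyl of compound 2 on the core.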